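The compounds below may be only part of what the source reports. "The series", "measured", "known", "first", "only" and "open" are said of these compounds alone.

Compound 1 `C#CCN(C)CCCOc1cc(NC(=O)CCCCCCC(=O)NO)c(Cl)cc1Cl` carries two chloro groups on its aromatic ring and a hydroxamic acid chain. In a functional assay on U-251 cells (Homo sapiens) for inhibition, read by MTT assay, with a stated time of 48 h (a higher number here means a weaker inhibitor, a lower number a stronger inhibitor), compound 1 gives 8670 nM. Among the two compounds measured so far, this is the highest number; the nearest is compound 2 `C#CCN(C)CCCOc1cccc(NC(=O)CCCCCCC(=O)NO)c1Cl`, which in this assay gives 4090 nM, a lower number that lies beyond the usual scatter. Compound 2 is not a single-point variant of compound 1, so its value is a comparison point only, not a step.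

The unmeasured compound 3 `C#CCN(C)CCCOc1cc(NC(=O)CCCCCCC(=O)NO)ccc1Cl` differs from compound 1 in one place: hydrogen in place of chloro on an aromatic carbon. The change sits on an aromatic carbon of a six-membered aromatic ring of carbon only, ortho to a large group, meta to a chloro group and para to a 3-(methyl(propargyl)amino)propoxy group.

For the measured compounds named here, with no single-point step in hand, the expectation for this assay rests on the two values alone. Compound 2, with a single chloro, shows 4090 nM, and compound 3 likewise keeps one chloro, so a modest move toward a lower number is expected, at the edge of the scatter, a 1.7-fold lower number from compound 1 to compound 3 (0.24 log units; within the scatter). Compound 3 is estimated at 5000 nM, within 2000 nM to 14000 nM.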

Compound 3, half-maximal inhibitory concentration: 600 nM
Compound 3: the middle estimate sits 8.3-fold (0.92 log units) above what was measured; the measured number lies below the stated range.
By their numbers in this assay, from the lowest: compound 3; then compound 2; then compound 1.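

In this assay, replacing chloro with hydrogen on this aromatic carbon gives the first single-change reading among these compounds, and the step is large: a 14-fold lower number from compound 1 to compound 3 (1.16 log units; beyond the scatter). Compound 1 and compound 2 differ in more than one place and could not isolate this position, whereas this step shows that the group on this one carbon, ortho to a large group, meta to a chloro group and para to a 3-(methyl(propargyl)amino)propoxy group, strongly affects the number in this cell assay, even though the change removes only one chlorine atom and leaves the hydrogen-bond donor and acceptor counts and the net charge unchanged. Nothing measured here accounts for the size of this step.

The compounds shown leave open whether fluoro, methyl, methoxy or nitrile on this carbon would give a number closer to that of compound 1 or that of compound 3, and so whether the step is specific to chloro. They also leave open whether the same change would have a similar effect with the remaining chloro group replaced by hydrogen or with a longer chain leading to the hydroxamic acid.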